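Removing the Methyl from a Methylamino Group

A few compounds are considered here, and "the series" means these few. Any claim that something is new, unique, unknown or untested is made for them only; others in the source may bear on it.

Three compounds share one core and differ only in the group carried on a single aromatic carbon. Compound 1 `CCCc1ccccc1N1CCN(CCCCCC(=O)NC2CCCc3ccccc32)CC1` carries a propyl group there, and in an assay on HEK293 cells for displacement of a labelled ligand from 5-hydroxytryptamine receptor 7 (Rattus norvegicus) (on this read-out higher numbers stand for weaker inhibition and lower numbers for stronger inhibition), compound 1 gives 49.6 nM. Compound 2 `CCCCc1ccccc1N1CCN(CCCCCC(=O)NC2CCCc3ccccc32)CC1` carries a butyl group, and compound 2 gives 2810 nM; the step of a 57-fold higher number from compound 1 to compound 2 (1.75 log units; beyond the scatter) is large. Compound 3 `CNc1ccccc1N1CCN(CCCCCC(=O)NC2CCCc3ccccc32)CC1` carries a methylamino group, and compound 3 gives 25.4 nM; among the three this is the lowest number, though the gap to compound 1 is within the scatter and only compound 2 lies clearly apart. Compound 4 `Nc1ccccc1N1CCN(CCCCCC(=O)NC2CCCc3ccccc32)CC1` comes next: hydrogen in place of methyl on a nitrogen on an aromatic ring. Among the compounds with values here, of the measured steps, a 2.0-fold lower number from compound 1 to compound 3 (0.29 log units; within the scatter) and a 110-fold lower number from compound 2 to compound 3 (2.04 log units; beyond the scatter) concern exchanges at the same aromatic carbon, but neither removes a methyl from a nitrogen, so no measured step speaks directly to this change. The change removes one carbon, and the step of a 1.2-fold higher number from compound 3 to compound 4 (0.07 log units; within the scatter) is expected to stay within the scatter. Compound 4 is therefore estimated at 30 nM, with a range from 10 nM to 100 nM.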

Compound 4, inhibition constant: 8180 nM
The estimate for compound 4 lay 270-fold (2.44 log units) below the measured number, and the stated range ends below it.
By their numbers in this assay, from the lowest: compounds 3 and 1 (each within the scatter of the next); then compound 2; then compound 4.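

In this assay the methyl on this nitrogen counts for far more than its single carbon might suggest, with a 320-fold higher number from compound 3 to compound 4 (2.51 log units; beyond the scatter) on its loss. The amino group also falls behind both alkyl groups, with a 160-fold higher number from compound 1 to compound 4 (2.22 log units; beyond the scatter) against propyl and a 2.9-fold higher number from compound 2 to compound 4 (0.46 log units; beyond the scatter) against butyl, which makes compound 4 the weakest of the four. No measured evidence here explains why one methyl matters so much.

The compounds shown leave open whether any substituent on this nitrogen would do, or only a methyl: an ethylamino or a dimethylamino group on the same aromatic carbon would test that. They also leave open whether a methoxy group, with oxygen in place of the nitrogen, would give a low number like those of compound 3 and compound 1.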